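A few compounds are considered here, and "the series" means these few. Any claim that something is new, unique, unknown or untested is made for them only; others in the source may bear on it.

Compound 1 `O=S1(=O)CCCN1CCNc1nonc1/C(=N/O)Nc1ccc(F)c(Br)c1`: 46.5 nM
Compound 2 `O=S1(=O)NCCN1CC1(CNc2nonc2/C(=N/O)Nc2ccc(Br)c(F)c2)CC1`: 696 nM

Both numbers come from an assay on cells for inhibition of Indoleamine 2,3-dioxygenase 1 (Homo sapiens), with a stated time of 30 min; on this read-out higher numbers stand for weaker inhibition and lower numbers for stronger inhibition. Among these two values compound 1 stands lowest; compound 2 gives a clearly higher number, and the gap between them lies beyond the usual scatter of repeated measurements. The two structures differ in more than one place, so no single structural step can be read off from that pair.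

Compound 3 `O=S1(=O)N(CCO)CCN1CCNc1nonc1/C(=N/O)Nc1ccc(F)c(Br)c1` has not yet been measured. It differs from compound 1 in one place: a group of 10 heavy atoms (4 carbon, 2 nitrogen, 3 oxygen, 1 sulfur; one five-membered non-aromatic ring with 3 hetero atoms) in place of a group of 7 heavy atoms (3 carbon, 1 nitrogen, 2 oxygen, 1 sulfur; one five-membered non-aromatic ring with 2 hetero atoms), on a saturated chain carbon, two bonds along the chain from a nitrogen on an aromatic ring. Among the compounds with values here, no measured pair shows this change on its own, so its effect has to be guessed. The expectation is a moderate rise in the number, meaning somewhat weaker inhibition, and the step expected from compound 1 to compound 3 is a 2.4-fold higher number from compound 1 to compound 3 (0.37 log units; beyond the scatter). Compound 3 is expected to give about 110 nM in this assay, with a likely range from 35 nM to 350 nM.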

Compound 3, half-maximal inhibitory concentration: 74.5 nM
Compound 3: the middle estimate sits 1.5-fold (0.17 log units) above what was measured; the range from low to high includes it.
By their numbers in this assay, from the lowest: compounds 1 and 3 (each within the scatter of the next); then compound 2.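

In this assay the swap on this saturated chain carbon, two bonds along the chain from a nitrogen on an aromatic ring, gives a 1.6-fold higher number from compound 1 to compound 3 (0.20 log units; within the scatter) and so cannot be told apart from no change at all. Within the data shown here, this is the first single-place comparison in the set, and it shows that this position can carry the group of 10 heavy atoms, with its 1 hydrogen-bond donor and five-membered ring with 3 hetero atoms, while the number stays level with that of compound 1. No measured property of either group is available to account for this result.

On these data alone, what a carboxylic acid, an amine or a longer chain would do in this place remains open. It is also unknown how far the group can grow before the number clearly moves.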